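The source may report more compounds than this note shows. Statements on the series, on what has been measured and on what is new or still open speak of the compounds shown alone.

Measured so far in a functional assay on MDA-MB-468 cells (Homo sapiens) for inhibition, read by WST assay, with a stated time of 48 h; a lower number here means a stronger inhibitor, a higher number a weaker inhibitor:
- compound 1 `S=C(N/N=C\c1ccc(Cl)cc1)NC1CCCCC1` gives 41600 nM
- compound 2 `CN(C)c1ccc(/C=N\NC(=S)NC2CCCCC2)cc1` gives 280000 nM
- compound 3 `Oc1cccc(/C=N\NC(=S)NC2CCCCC2)c1` gives 32200 nM

Compound 1 stands second highest of the three numbers in this assay; compound 3 is within the scatter of it, and compound 2 gives the highest number of the three.

Compound 4 `CCOc1ccc(/C=N\NC(=S)NC2CCCCC2)cc1` differs from compound 1 by ethoxy in place of chloro on an aromatic carbon. For the measured compounds named here, one measured step bears on this site: a 6.7-fold higher number from compound 1 to compound 2 (0.83 log units; beyond the scatter), where a dimethylamino entered in place of the chloro. An ethoxy on the same carbon is expected to move the number in the same direction but by less, so the step is estimated as a 1.7-fold higher number from compound 1 to compound 4 (0.23 log units; within the scatter) in this assay. Compound 4 is therefore expected to give about 70000 nM in this assay, with a range from 25000 nM to 200000 nM.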

Compound 4, half-maximal inhibitory concentration: 252000 nM
The estimate for compound 4 lay 3.6-fold (0.56 log units) below the measured number; the whole stated range lies below it.
By their numbers in this assay, from the lowest: compounds 3 and 1 (each within the scatter of the next); then compounds 4 and 2 (each within the scatter of the next).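

In this assay, ethoxy in place of chloro, para to a large group, gives a 6.1-fold higher number from compound 1 to compound 4 (0.78 log units; beyond the scatter), so the rise seen earlier is not particular to dimethylamino. The two replacements for chloro cannot be told apart, with a 1.1-fold lower number from compound 2 to compound 4 (0.05 log units; within the scatter) lying within the scatter. No measured evidence here accounts for the shift away from chloro. As far as these compounds go, whether methyl, fluoro or a carboxylic acid on this carbon stays close to compound 1 or falls with compound 2 and compound 4 remains open.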